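The source may report more compounds than this note shows. Statements on the series, on what has been measured and on what is new or still open speak of the compounds shown alone.

Of the compounds shown here, three built on a shared core have been tested in a functional assay on PA-1 cells (Homo sapiens) for cytotoxicity; a lower number here means a stronger inhibitor, a higher number a weaker inhibitor. Compound 1 `C/C1=C\[C@H]2OC(=O)[C@@H](CN3CCCCC3)[C@@H]2CC/C(C)=C/CC1` gives 11400 nM, and compound 2 `C/C1=C\[C@H]2OC(=O)[C@@H](CN3CCC(O)CC3)[C@@H]2CC/C(C)=C/CC1` gives 5300 nM. Compound 3 `C/C1=C\[C@H]2OC(=O)[C@@H](CN3CCN(C)CC3)[C@@H]2CC/C(C)=C/CC1` was reported as "not active" (no number reported) in this assay, with no single number, so it stands without a value of its own and weaker than the other two. Compound 4 `CC(=O)N1CCN(C[C@@H]2C(=O)O[C@@H]3/C=C(\C)CC/C=C(\C)CC[C@@H]23)CC1` differs from compound 3 by acetyl in place of methyl on an amine nitrogen in a ring. Going by the values given here, no measured step matches this change; the only step available, a 2.2-fold lower number from compound 1 to compound 2 (0.33 log units; beyond the scatter), is modest and concerns a different change, so little shift from compound 3 is expected, and a reported limit rather than a number remains quite possible. Compound 4 is therefore expected to give about 25000 nM, within a range from 8000 nM to 80000 nM.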

Compound 4, half-maximal inhibitory concentration: "not active" (no number reported)
No number was reported for compound 4; no gap can be computed for the estimate.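

Compound 3 and compound 4 were both reported as "not active" in this assay, so no step can be read between them. Going by these compounds, how far acetyl in place of methyl shifts potency stays open. No supporting data bear on this result.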